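The compounds below may be only part of what the source reports. "The series", "measured", "known", "first", "only" and "open" are said of these compounds alone.

Compound 1, `O=C(O)CC/C=C\CO[C@H]1[C@@H](OCc2ccc(-c3ccccc3)cc2)CC[C@@H]1N1CCCCC1`: in a functional assay for antagonist activity at thromboxane A2 receptor (Rattus norvegicus) (on this read-out lower numbers stand for tighter binding and higher numbers for weaker binding), compound 1 gives 31.6 nM; 50.1 nM (2 entries).
Compound 2, `NC(=O)Cc1ccccc1-c1ccc(COC2CC[C@H](N3CCCCCC3)[C@H]2OC/C=C\CCC(=O)O)cc1`: in this assay compound 2 gives 158 nM.
Compound 3, `O=C(O)CC/C=C\CO[C@H]1C(OCc2ccc(-c3ccccc3CCO)cc2)CC[C@@H]1N1CCCCCC1`: in this assay compound 3 gives 31.6 nM.

Compound 3 holds the lowest of the two single numbers; compound 2 is its nearest neighbour, and compound 1, with two entries and no single number, sits close to it. Within the data shown here, the only step measured in one place is a 5.0-fold lower number from compound 2 to compound 3 (0.70 log units; beyond the scatter), a swap of one group on the pendant phenyl ring. The spread of the repeats of compound 1, (the several entries of compound 1 in this assay, 31.6 nM; 50.1 nM (2 entries)), shows how much two runs of the same compound can differ.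

Compound 4, `CS(=O)(=O)Nc1cccc(-c2ccc(COC3CC[C@H](N4CCCCCC4)[C@H]3OC/C=C\CCC(=O)O)cc2)c1`, changes that same pendant ring once more: 3-(methanesulfonamido)phenyl in place of 2-(2-hydroxyethyl)phenyl on an aromatic carbon. Among the measured compounds shown here, the one measured step at this ring was modest, and no entry tells how a methanesulfonamido group behaves here, so only a small shift in either direction is expected, most likely none beyond the scatter. Compound 4 is therefore estimated to give 50 nM, with a range of 15 nM to 160 nM. This expectation corresponds to a 1.6-fold higher number from compound 3 to compound 4 (0.20 log units; within the scatter).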

Compound 4, dissociation constant: 50.1 nM
Compound 4: the middle estimate sits 1.0-fold (0.00 log units) below what was measured, and the stated range covers the measured number.
By their numbers in this assay, from the lowest: compounds 3 and 4 (each within the scatter of the next); then compound 2.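

The pendant ring can carry two quite different groups, 2-(2-hydroxyethyl)phenyl and 3-(methanesulfonamido)phenyl, without a difference that can be told apart in this assay: the step is a 1.6-fold higher number from compound 3 to compound 4 (0.20 log units; within the scatter). Compound 4 also reads clearly apart from the carbamoyl-bearing group, with a 3.2-fold lower number from compound 2 to compound 4 (0.50 log units; beyond the scatter), so compound 2 is now set apart from two different replacements rather than one. The gap between compound 3 and compound 4 is no wider than the one between repeats of a single compound: the several entries of compound 1 in this assay, 31.6 nM; 50.1 nM (2 entries).

In going to compound 4, both the group and its place on the ring change, so the contribution of each cannot be separated. Going by these compounds, it also remains open how a simple amine or a carboxylic acid on this ring would read in this assay.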